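From phenyl to 4-nitrophenyl in the series

The compounds below may be only part of what the source reports. "The series", "measured", "known", "first", "only" and "open" are said of these compounds alone.

In a functional assay on MT4 cells (Homo sapiens) for cytotoxicity, read by MTT assay (on this read-out higher numbers stand for lower toxicity in this test and lower numbers for higher toxicity in this test), compound 2 `Cc1c(O)nc(SCc2ccccc2)nc1Cc1c(Cl)cccc1Cl` stands at > 64000 nM, which is a limit and not a number. Compound 1 `Cc1c(O)nc(SCc2ccc(O)cc2)nc1Cc1c(Cl)cccc1Cl` gives 41000 nM in this assay. Compound 3 `Cc1c(O)nc(SCc2ccc([N+](=O)[O-])cc2)nc1Cc1c(Cl)cccc1Cl` carries nitro in place of hydrogen on an aromatic carbon, para to a large group: nitro in place of hydrogen on an aromatic carbon. Going by the values given here, the one measured step bearing on this is an at least 1.5-fold higher number from compound 1 to compound 2 (0.19 log units; that floor lies within the scatter), and its floor lies within the scatter. The step expected in this assay is an at least 1.4-fold lower number from compound 2 to compound 3 (0.15 log units; that floor lies within the scatter), no larger than the scatter. The estimate for compound 3 is 45000 nM, with an expected range of 15000 nM to 100000 nM.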

Compound 3, half-maximal cytotoxic concentration: > 58000 nM
Compound 3 ended at the assay's limit (the forecaster's own chance of this, stated with the estimate: 45%); middle value at least 1.2-fold (0.11 log units) from the limit.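

In this assay compound 3 gives > 58000 nM, a second limit on this aromatic carbon and not a number: the limit of > 58000 nM in this assay, at which 1 of the 3 values shown sits. The step between compound 2 and compound 3 cannot be read, as both values are limits. Nitro in place of hydroxy shows an at least 1.4-fold higher number from compound 1 to compound 3 (0.15 log units; that floor lies within the scatter), so this change gives no step readable beyond the scatter.

Open, on these data alone, is whether an amine or a carboxylic acid on this aromatic carbon, para to a large group, would give a number rather than a limit in this assay.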